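A few compounds are considered here, and "the series" means these few. Any claim that something is new, unique, unknown or untested is made for them only; others in the source may bear on it.

Compound 2, `COc1ccc(-n2nc(-c3ccccc3)nc2CNc2ccc(C(=O)NO)cc2)cc1`, gives 63.4% in an assay on Sf9 cells for inhibition of protein deacetylase HDAC6 (Homo sapiens), read by fluorescence, with a stated time of 40 min, tested at 100 nM; on this read-out higher numbers stand for more inhibition at the one concentration tested (going by the name of the read-out) and lower numbers for less inhibition. That number is the largest of the three measured, but compound 1, `Cc1ccc(-c2nc(CNc3ccc(C(=O)NO)cc3)n(-c3ccccc3)n2)cc1`, sits within the usual scatter of it with 62.2%, while compound 3, `NNC(=O)c1ccc(NCc2nc(-c3ccccc3)nn2-c2ccccc2)cc1`, gives 10%, a number far lower than that of compound 2. Compound 4, `CC(C)c1ccc(-n2nc(-c3ccccc3)nc2CNc2ccc(C(=O)NO)cc2)cc1`, is not yet measured; it differs from compound 2 by isopropyl in place of methoxy on an aromatic carbon. Compounds 1 and 2 carry different groups on the same part of the molecule and give numbers that are level with each other in this assay. The step from compound 2 to compound 4 is therefore expected to be a number 3.4 percentage points lower from compound 2 to compound 4 (within the scatter), that is, none beyond the scatter. Compound 4 is expected to give about 60%, within a range of 42% to 75%.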

Compound 4, a percentage reported as inhibition, at one concentration (the size of the read-out at that concentration, not a potency): 52.6%
The estimate for compound 4 lay 7.4 percentage points above the measured number; the range from low to high includes it.
By their numbers in this assay, from the lowest: compound 3; then compounds 4, 1 and 2 (each within the scatter of the next, the first and the last beyond it).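

In this assay, the step from 4-methoxyphenyl to 4-isopropylphenyl gives a number 10.8 percentage points lower from compound 2 to compound 4 (beyond the scatter), so the read-out at this position does respond to the group it carries, though modestly. For the compounds shown here, the earlier compounds offered no single-place step, so this is the first such change to be read at this position. Nothing available bears on the reason for the drop. An ethoxy group or an amine at this place could help show whether the step follows the oxygen that leaves or the carbons that enter. From the compounds shown here alone, how a carboxylic acid would read here also remains open.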